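A Cyclobutylsulfanyl Group Replaces a Cyano-Bearing Chain

The source may hold more compounds than are shown below. What is called first, only, known or untested is meant among the compounds shown, and "the series" means these compounds.

Compound 1 `Cc1nc(S(C)(=O)=O)ccc1Oc1ncnc(OC2CCN(C(=O)OC(C)(C)C#N)CC2)c1F`: 1320 nM
Compound 2 `Cc1nc(S(C)(=O)=O)ccc1Oc1ncnc(OC2CCN(C(=O)OC(C)(C)CF)CC2)c1F`: 138 nM
Compound 3 `Cc1nc(S(C)(=O)=O)ccc1Oc1ncnc(OC2CCN(C(=O)O[C@H](C)CF)CC2)c1F`: 1520 nM

In a functional assay on isolated protein for inhibition of Glucose-dependent insulinotropic receptor (Rattus norvegicus), read by HTRF and cAMP accumulation (on this read-out higher numbers stand for an effect only at larger amounts of compound and lower numbers for an effect already at smaller amounts), compound 1 stands second highest of the three numbers. Its nearest neighbour is seen in a 1.2-fold higher number from compound 1 to compound 3 (0.06 log units; within the scatter); its furthest in a 9.6-fold lower number from compound 1 to compound 2 (0.98 log units; beyond the scatter).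

Compound 4 `Cc1nc(S(C)(=O)=O)ccc1Oc1ncnc(OC2CCN(C(=O)SC3CCC3)CC2)c1F` differs from compound 1 in one place: cyclobutylsulfanyl in place of 1-cyano-1-methylethoxy on a carbonyl carbon. Within the data shown here, no measured step makes this exact change, so the guidance is indirect. The step of a 9.6-fold lower number from compound 1 to compound 2 (0.98 log units; beyond the scatter) shows that giving up the cyano brought a markedly lower number, and an 11-fold higher number from compound 2 to compound 3 (1.04 log units; beyond the scatter) shows that trimming a methyl brought a large rise. Compound 4 likewise gives up the cyano while keeping comparable bulk, so a modestly lower number is expected: a 2.9-fold lower number from compound 1 to compound 4 (0.47 log units; beyond the scatter). For compound 4 the value is estimated at 450 nM, with a range from 100 nM to 2000 nM.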

Compound 4, half-maximal effective concentration: 77.4 nM
Compound 4: middle estimate off by 5.8-fold (0.76 log units), on the high side; measured number outside the range, below it.
By their numbers in this assay, from the lowest: compounds 4 and 2 (each within the scatter of the next); then compounds 1 and 3 (each within the scatter of the next).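

The carbonyl carbon does not need an oxygen-linked chain to reach low numbers: cyclobutylsulfanyl, with its sulfur and four-membered ring, gives a 17-fold lower number from compound 1 to compound 4 (1.23 log units; beyond the scatter) and a 20-fold lower number from compound 3 to compound 4 (1.29 log units; beyond the scatter). A structurally different group thus lands level with the earlier low number, as seen in a 1.8-fold lower number from compound 2 to compound 4 (0.25 log units; within the scatter). Nothing measured here explains this result. On these data alone, whether the gain belongs to the sulfur or to the ring stays open: cyclobutyloxy, or an open-chain group such as tert-butylsulfanyl, would separate the two.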